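This account rests on a few compounds, and the source may have more. Where it says the series, first, only, none or still open, it means among the compounds named here.

Two measured compounds share the core of compound 1 `CC(O)(C(=O)Nc1ccc(S(=O)(=O)c2ccccc2)c(F)c1)C(F)(F)F`. In a functional assay (Cavia porcellus) with sulfonylurea receptors; K-ATP channels (Homo sapiens) as the target (on this read-out higher numbers stand for weaker inhibition and lower numbers for stronger inhibition), compound 1 gives 1800 nM. Compound 2 `CC(O)(C(=O)Nc1ccc(S(=O)(=O)c2ccc(C#N)cc2)cc1)C(F)(F)F` reaches only the limit of this assay, > 30000 nM, and no number stands behind it; (the limit of > 30000 nM in this assay, at which 1 of the 2 values shown sits). Compound 3 `CC(O)(C(=O)Nc1ccc(S(=O)(=O)c2cnccn2)cc1)C(F)(F)F` is not yet measured. The change from compound 2 is pyrazin-2-yl in place of 4-cyanophenyl on a sulfonyl sulfur. Among the compounds with values here, no measured pair shows this change, so its size is open. The step meant by the estimate, an at least 1.5-fold lower number from compound 2 to compound 3 (0.17 log units; that floor lies within the scatter), is expected not to exceed the scatter, with weak inhibition remaining. For compound 3 the expected value is 20000 nM, within 5000 nM to 60000 nM.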

Compound 3, half-maximal inhibitory concentration: 12000 nM
Beside the measured number, compound 3's estimate is 1.7-fold (0.22 log units) above it; the measured number falls inside the stated range.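

Within the data shown here, on the sulfonyl sulfur, pyrazin-2-yl in place of 4-cyanophenyl gives the first readable step at this position in this assay: an at least 2.5-fold lower number from compound 2 to compound 3 (0.39 log units; beyond the scatter). The group on this sulfur can therefore move the read-out beyond the scatter, and compound 3 gives a true number rather than a limit. Compound 2 holds only a limit, so the step fixes a floor and not a size: the limit of > 30000 nM in this assay, at which 1 of the 3 values shown sits.

Going by these compounds, whether the nitrile or the ring carries the step stays open, and so does the reading of a pyridin-2-yl or an aminophenyl group on the same sulfur. Compound 1 differs from compound 3 in more than one place, so that pair gives no comparison for this position.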